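The source may hold more compounds than are shown below. What is called first, only, known or untested is meant among the compounds shown, and "the series" means these compounds.

Compound 2 `O=C1/C(=C/c2ccccc2)CN(C(=O)CCSCCO)C/C1=C\c1ccccc1` gives 1530 nM in a functional assay on HSC-2 cells (Homo sapiens) for cytotoxicity, read by MTT assay, with a stated time of 48 h; on this read-out lower numbers stand for higher toxicity in this test and higher numbers for lower toxicity in this test. Compound 1 `O=C1/C(=C/c2ccccc2)CN(C(=O)CCSCCS(=O)(=O)O)C/C1=C\c1ccccc1` carries sulfo in place of hydroxy on a saturated chain carbon, two bonds along the chain from a sulfur and gives 154000 nM in this assay, so that a 100-fold higher number from compound 2 to compound 1 (2.00 log units; beyond the scatter). Compound 3 `O=C1/C(=C/c2ccc([N+](=O)[O-])cc2)CN(C(=O)CCSCCO)C/C1=C\c1ccc([N+](=O)[O-])cc1` rests on a different core; the difference between the two cores is not broken down here. In this assay compound 3 gives 390 nM, the lowest number of the three measured compounds. Compound 4 `O=C1/C(=C/c2ccc([N+](=O)[O-])cc2)CN(C(=O)CCSCCS(=O)(=O)O)C/C1=C\c1ccc([N+](=O)[O-])cc1` stands to compound 3 as compound 1 stands to compound 2, through (sulfo in place of hydroxy on a saturated chain carbon, two bonds along the chain from a sulfur), the same change at the same place. A step of similar size is expected for compound 4, a 77-fold higher number from compound 3 to compound 4 (1.89 log units; beyond the scatter), because a 100-fold higher number from compound 2 to compound 1 (2.00 log units; beyond the scatter) arose from the same change, though that single pair sits on a different core. Compound 4 is therefore estimated at 30000 nM. The value of compound 4 is expected to fall between 8000 nM and 120000 nM.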

Compound 4, half-maximal cytotoxic concentration: 4730 nM
Compound 4: the middle estimate sits 6.3-fold (0.80 log units) above what was measured; the measured number lies below the stated range.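

In this assay the change from hydroxy to sulfo again gave a 12-fold higher number from compound 3 to compound 4 (1.08 log units; beyond the scatter). The direction of the step carried over from one core to the other, but its size did not: the same change on two cores in this assay, a 100-fold higher number (2.00 log units; beyond the scatter) from compound 2 to compound 1 and a 12-fold higher number (1.08 log units; beyond the scatter) from compound 3 to compound 4, 8.3-fold (0.92 log units) apart, beyond the scatter of two such steps. These two pairs show that the change gives a higher number on both cores, but they do not show why the size differs or predict the size of the step on a further core.

The compounds shown leave open whether a carboxylic acid or an amine in place of the sulfo group, or a longer chain in place of the 2-sulfoethyl group, would give a similar step. They also leave open how the step would run on a core carrying chloro or methoxy groups in place of nitro.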